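The source may report more compounds than this note shows. Statements on the series, on what has been measured and on what is new or still open speak of the compounds shown alone.

In an ADME assay on microsomes from liver (Rattus norvegicus) for metabolic stability, with a stated time of 10 min (a higher number here means that more of the compound is left, a lower number that less of the compound is left), compound 1 (`Fc1ccccc1-c1ccc2[nH]c(C3=NOC4(CCCCC4)C3)nc2c1`) gives 55%, compound 2 (`FC(F)(F)Oc1ccccc1-c1ccc2[nH]c(C3=NOC4(CCCCC4)C3)nc2c1`) gives 74%, and compound 3 (`Fc1ccccc1-c1cc(C(F)(F)F)c2[nH]c(C3=NOC4(CCCCC4)C3)nc2c1`) gives 100%, the highest of the three. Compound 4 (`FC(F)(F)Oc1ccccc1-c1cc(C(F)(F)F)c2[nH]c(C3=NOC4(CCCCC4)C3)nc2c1`) has trifluoromethoxy in place of fluoro on an aromatic carbon, ortho to a large group: trifluoromethoxy in place of fluoro on an aromatic carbon. The same exchange has been measured once, in a number 19 percentage points higher from compound 1 to compound 2 (beyond the scatter), a modest step upward. The other measured step, a number 45 percentage points higher from compound 1 to compound 3 (beyond the scatter), is large and introduces the trifluoromethyl group that compound 3 and compound 4 share. Taken alone, these two steps would point upward, but the read-out cannot climb beyond all of the compound remaining, and compound 3 already stands at 100%. No rise beyond the scatter is therefore expected in this assay, and the estimated change is a number 4 percentage points lower from compound 3 to compound 4 (within the scatter), a small one within the scatter. For compound 4 the expected value is 96%, with an estimated range from 84% to 100%.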

Compound 4, percent of the compound remaining: 53%
Estimate against measurement, compound 4: 43 percentage points above, and the stated range ends above it.
By their numbers in this assay, from the lowest: compounds 4 and 1 (each within the scatter of the next); then compound 2; then compound 3.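

Trifluoromethoxy in place of fluoro, on an aromatic carbon ortho to a large group, does not behave the same way once trifluoromethyl is on the core. In this assay it gives a number 47 percentage points lower from compound 3 to compound 4 (beyond the scatter), so the outcome of this exchange depends on the core that carries it: the same change on two cores in this assay, a number 19 percentage points higher (beyond the scatter) from compound 1 to compound 2 and a number 47 percentage points lower (beyond the scatter) from compound 3 to compound 4, 66 percentage points apart, beyond the scatter of two such steps. The trifluoromethyl change turns out to depend on its partner in the same way, with a number 21 percentage points lower from compound 2 to compound 4 (beyond the scatter) once 2-(trifluoromethoxy)phenyl is present: the same change on two cores in this assay, a number 45 percentage points higher (beyond the scatter) from compound 1 to compound 3 and a number 21 percentage points lower (beyond the scatter) from compound 2 to compound 4, 66 percentage points apart, beyond the scatter of two such steps. Among these four compounds, each change goes with a higher number when the other is absent and a lower one when the other is present.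

The compounds shown do not tell which part of compound 4 is lost in the microsomes. As far as these compounds go, it also remains open how methoxy, chloro or a nitrile would fare at this position on the trifluoromethyl core.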